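Vinyl sulfonate esters with methoxyphenyl and chlorophenyl ends

The source may report more compounds than this note shows. Statements on the series, on what has been measured and on what is new or still open speak of the compounds shown alone.

Measured compounds:
compound 1, `COc1cccc(OS(=O)(=O)/C=C/c2cccc(Cl)c2)c1`, 943 nM
compound 2, `COc1ccc(OS(=O)(=O)/C=C/c2cccc(Cl)c2)cc1`, 948 nM
compound 3, `COc1cccc(OS(=O)(=O)/C=C/c2ccc(Cl)cc2)c1`, 1780 nM

In an assay on U2OS cells for activation of nuclear factor erythroid 2-related factor 2 (Homo sapiens), read by chemiluminescence, with a stated time of 6 h (a lower number here means that less compound is needed, a higher number that more compound is needed for the effect), compound 1 gives 943 nM and compound 2 gives 948 nM; these two values lie within the scatter of each other, so no order between them can be read. Compound 3 gives 1780 nM in this assay. Among the measured compounds shown here, the one counted step among the measured compounds is a 1.9-fold higher number from compound 1 to compound 3 (0.28 log units; within the scatter), and the change behind it is 4-chlorophenyl in place of 3-chlorophenyl on a double-bonded chain carbon bound to a double-bonded chain carbon. The cores of compound 1 and compound 2 both carry a methoxy group on the phenyl sulfonate ester, but the difference between the two cores is not broken down here.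

Compound 4, `COc1ccc(OS(=O)(=O)/C=C/c2ccc(Cl)cc2)cc1`, has not yet been measured in this assay. It stands to compound 2 as compound 3 stands to compound 1, the change being (4-chlorophenyl in place of 3-chlorophenyl on a double-bonded chain carbon bound to a double-bonded chain carbon); the place is the same as in the measured pair, so this is the same change, seen twice in the set.

The step for compound 4 is expected to be a 1.9-fold higher number from compound 2 to compound 4 (0.28 log units; within the scatter), set beside a 1.9-fold higher number from compound 1 to compound 3 (0.28 log units; within the scatter). For the measured compounds named here, this rests on compound 2 giving 948 nM and on the single measured instance of the change, a 1.9-fold higher number from compound 1 to compound 3 (0.28 log units; within the scatter), which itself lies within the scatter, so the direction is not secure. Compound 4 is therefore estimated at 1800 nM, with a range from 900 nM to 3600 nM in this assay.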

Compound 4, half-maximal effective concentration: 1160 nM
Estimate against measurement, compound 4: 1.6-fold (0.19 log units) above; the measured number falls inside the stated range.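

On the core of compound 2, 4-chlorophenyl in place of 3-chlorophenyl gives a 1.2-fold higher number from compound 2 to compound 4 (0.09 log units; within the scatter) in this assay, so this second instance of the change also stays inside the usual variation between repeats. Set beside the first instance, the change reads alike on the two cores, with no difference between them that can be told from the scatter: the same change on two cores in this assay, a 1.9-fold higher number (0.28 log units; within the scatter) from compound 1 to compound 3 and a 1.2-fold higher number (0.09 log units; within the scatter) from compound 2 to compound 4, 1.5-fold (0.19 log units) apart, within the scatter of two such steps. This shows that nothing in the two steps separates one core from the other, but it does not show that the change carries over as a real effect: neither step is large enough to fix a direction, so a shared upward trend cannot be claimed, and agreement between two small steps on two cores says little about any further core.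

All four compounds pair a methoxyphenyl sulfonate end with a chlorophenyl end, so the series as shown gives no step that clearly exceeds the scatter and no view of how far the number can move. Open questions are whether a nitrile, a carboxylic acid or an amine in place of the chlorine, or a longer chain such as ethoxy or butoxy in place of the methoxy group, would give such a step.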